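Nitro substitution on the aryl ether end of compound 2

The source may hold more compounds than are shown below. What is called first, only, known or untested is meant among the compounds shown, and "the series" means these compounds.

The series is followed in a functional assay on NCI-H460 cells (Homo sapiens) for inhibition, tested at 100 uM; a lower number here means less inhibition, a higher number more inhibition at the concentration tested (going by the name of the read-out). Compound 1 `CC(=O)Nc1ccsc1C#CC(C)(C)O` gives 56% there. Among the compounds with values here, compound 2 `C(#Cc1cccs1)COc1ccccc1` gives 88% in this assay, the highest of the two numbers so far; its nearest neighbour is compound 1, whose number lies lower by a margin beyond the usual scatter. Within the data shown here, no pair of measured compounds differs in a single place, so no measured step is available to calibrate the change now under consideration.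

Compound 3 `O=[N+]([O-])c1ccc(OCC#Cc2cccs2)cc1` differs from compound 2 by nitro in place of hydrogen on an aromatic carbon. The change sits on an aromatic carbon of a six-membered aromatic ring of carbon only, at the end of the molecule remote from the thiophene-bearing alkyne. Compound 2 already sits high in this assay, so there is little room upward. The step from compound 2 to compound 3 is expected to be small, most likely within the scatter, with a slight risk of a drop: a number 3 percentage points lower from compound 2 to compound 3 (within the scatter). Compound 3 is therefore estimated at 85% in this assay, with a range from 65% to 98%.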

Compound 3, a percentage reported as inhibition, at one concentration (the size of the read-out at that concentration, not a potency): 48%
Compound 3: middle estimate off by 37 percentage points, on the high side, outside the stated range (below it).
By their numbers in this assay, from the lowest: compounds 3 and 1 (each within the scatter of the next); then compound 2.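

In this assay, within the data shown here, nitro in place of hydrogen on an aromatic carbon brings a number 40 percentage points lower from compound 2 to compound 3 (beyond the scatter) and this is the first single-place change measured, so this position on the six-membered aromatic ring of carbon only is not indifferent to substitution. The high number of compound 2 therefore does not carry over to its nitro analogue: a single nitro of 3 heavy atoms, para to a group of 9 heavy atoms, removes much of the inhibition seen at the concentration tested. Nothing shown bears on the reason for this fall, and it stays unassigned.

A single step cannot say whether the loss belongs to nitro itself or would follow any substituent on this carbon; an amine, a methoxy group or a chlorine atom at the same place would separate those two readings. Among these compounds, it also remains open whether nitro on another carbon of the same ring gives a step of similar size, and a percentage at one concentration gives no potency for either compound.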